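Phenyl on the amide nitrogen of an inactive pair

A few compounds are considered here, and "the series" means these few. Any claim that something is new, unique, unknown or untested is made for them only; others in the source may bear on it.

Measured in a functional assay on HCT-116 cells (Homo sapiens) for antiproliferative activity, read by MTT assay, with a stated time of 72 h (on this read-out lower numbers stand for stronger inhibition and higher numbers for weaker inhibition), so far:
Compound 1 `COc1ccc(N2C(=O)COc3ccc(-c4cnc5ccccc5c4)cc32)cc1` gives > 40000 nM as a limit
Compound 2 `O=C1COc2ccc(-c3cnc4ccccc4c3)cc2N1` gives > 40000 nM as a limit

Compound 2 has no measured number, since its > 40000 nM is a limit of the assay. Both compounds rest at the limit of > 40000 nM in this assay, at which 2 of the 2 values shown sit, and so cannot be ranked. Compound 3 `O=C1COc2ccc(-c3cnc4ccccc4c3)cc2N1c1ccccc1` differs from compound 2 in one place: phenyl in place of hydrogen on an amide-type nitrogen in a ring. In words, this is phenyl in place of hydrogen on an amide-type nitrogen in a ring. Going by the values given here, the one measured step at that nitrogen is a step that the two limits leave unreadable from compound 1 to compound 2 and it offers no size to carry over. With neither hydrogen in compound 2 nor 4-methoxyphenyl in compound 1 giving a number, no step beyond the scatter is expected in this assay. The estimated step is a number no higher from compound 2 to compound 3 (the limit leaves the size open) and it is only a rough expectation. Compound 3 is expected near 40000 nM, with an estimated range from 15000 nM to 80000 nM and a limit as the likeliest report.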

Compound 3, half-maximal inhibitory concentration: > 40000 nM
Compound 3 gave a limit, no number; the forecaster's own chance of this, stated with the estimate: 75%; the middle value sits exactly at the limit.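

In this assay compound 3 gives > 40000 nM, a limit and not a number. No step among compound 1, compound 2 and compound 3 can be read, because all three rest at the same value: the limit of > 40000 nM in this assay, at which 3 of the 3 values shown sit.

From the compounds shown here alone, whether any group on the amide-type nitrogen can give a measurable number in this assay stays open.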